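The source may report more compounds than this note shows. Statements on the series, on what has been measured and on what is new or still open speak of the compounds shown alone.

Series notes, two measured compounds, values in an assay for inhibition of NADPH oxidase 4 (Homo sapiens), read by chemiluminescence; on this read-out higher numbers stand for weaker inhibition and lower numbers for stronger inhibition:

- compound 1, `CN1C(=S)N(C2CCCCC2)C(=O)/C1=C/c1cccc(O)c1O`: 6350 nM
- compound 2, `CCc1ccc(N2C(=O)/C(=C/c3ccc(O)cc3O)N(C)C2=S)cc1`: 2390 nM

Of these two numbers, compound 2 holds the lower one; compound 1 sits higher by a gap that lies beyond the usual scatter. The two differ at two places at once, both in the substituent on the ring nitrogen and in the hydroxyl pattern of the arylidene ring, so no single-change step can be read from them.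

Compound 3, `CCc1ccc(N2C(=O)/C(=C/c3cccc(O)c3O)N(C)C2=S)cc1`, is the not yet measured analogue of compound 2 with 2,3-dihydroxyphenyl in place of 2,4-dihydroxyphenyl on a double-bonded chain carbon bound to a double-bonded ring carbon. Only the arylidene ring changes; the rest of compound 2 is kept. Going by the values given here, the single comparison available, compound 1 against compound 2, goes in the direction of a higher number for the 2,3-dihydroxyphenyl compound, but is confounded by the nitrogen substituent and so carries little weight.

For compound 3 a modest rise in this assay is expected, a 1.7-fold higher number from compound 2 to compound 3 (0.22 log units; within the scatter), plausibly within or just beyond the scatter. The estimate for compound 3 is 4000 nM, with a range from 1500 nM to 11000 nM.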

Compound 3, inhibition constant: 26400 nM
The estimate for compound 3 lay 6.6-fold (0.82 log units) below the measured number; measured number above the stated range.
By their numbers in this assay, from the lowest: compound 2; then compound 1; then compound 3.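

In this assay, with everything else kept, 2,3-dihydroxyphenyl in place of 2,4-dihydroxyphenyl on a double-bonded chain carbon bound to a double-bonded ring carbon gives an 11-fold higher number from compound 2 to compound 3 (1.04 log units; beyond the scatter) and shows that the number depends strongly on the hydroxyl pattern of this ring, although the counted atoms, donors and acceptors stay the same. With 2,3-dihydroxyphenyl held fixed, 4-ethylphenyl in place of cyclohexyl on an amide-type nitrogen in a ring gives a 4.2-fold higher number from compound 1 to compound 3 (0.62 log units; beyond the scatter) as a second, smaller single-change step, so the nitrogen substituent also moves the number. Nothing measured here bears on the reason for either step.

The compounds shown leave open whether a single hydroxyl, a methoxy group or an amine on this ring would keep the number of compound 2. As far as these compounds go, whether the nitrogen step keeps its direction and size with 2,4-dihydroxyphenyl also remains open.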